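An Allyl Chain in Place of Isopropyl on the Shared Core

This account rests on a few compounds, and the source may have more. Where it says the series, first, only, none or still open, it means among the compounds named here.

Compound 1 `CCN(c1ccnc(Nc2ccc(C#N)cc2)n1)c1c(F)cc(-c2ccc(C#N)cc2)cc1F`: 105000 nM
Compound 2 `CC(C)N(c1ccnc(Nc2ccc(C#N)cc2)n1)c1c(F)cc(-c2ccc(C#N)cc2)cc1F`: 172000 nM
Compound 3 `N#Cc1ccc(Nc2nccc(N(CC(O)CO)c3c(F)cc(-c4ccc(C#N)cc4)cc3F)n2)cc1`: 19500 nM

These three compounds share one core and differ only in the chain on a nitrogen on an aromatic ring. In an ADME assay on MT4 cells (Homo sapiens) for cytotoxicity, read by MTT assay, with a stated time of 5 days (on this read-out higher numbers stand for lower toxicity in this test and lower numbers for higher toxicity in this test), compound 2 gives the highest of the three numbers, but its gap to compound 1 is small: the step of a 1.6-fold higher number from compound 1 to compound 2 (0.21 log units; within the scatter) lies within the scatter. Compound 3 stands well apart, as the steps of a 5.4-fold lower number from compound 1 to compound 3 (0.73 log units; beyond the scatter) and an 8.8-fold lower number from compound 2 to compound 3 (0.95 log units; beyond the scatter) show; both bring hydroxyl groups onto the chain.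

Compound 4 `C=CCN(c1ccnc(Nc2ccc(C#N)cc2)n1)c1c(F)cc(-c2ccc(C#N)cc2)cc1F` carries a change of a different kind: allyl in place of isopropyl on a nitrogen on an aromatic ring. No hydroxyl group enters, so the two steps to compound 3 bear little on it. Within the data shown here, the step that does bear on it is the one from compound 1 to compound 2, an exchange of one short chain for another without any donor or acceptor, and that step stayed within the scatter. On this basis compound 4 is expected to stay close to compound 2 in this assay, with an estimated step of a 1.1-fold lower number from compound 2 to compound 4 (0.06 log units; within the scatter), nothing beyond the scatter. Compound 4 is therefore estimated at 150000 nM, within a range from 70000 nM to 320000 nM.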

Compound 4, half-maximal cytotoxic concentration: 249000 nM
The estimate for compound 4 lay 1.7-fold (0.22 log units) below the measured number; the measured number falls inside the stated range.
By their numbers in this assay, from the lowest: compound 3; then compounds 1, 2 and 4 (each within the scatter of the next, the first and the last beyond it).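

Swapping isopropyl for allyl keeps the count of three carbons and adds a double bond outside aromatic rings, and in this assay the step of a 1.4-fold higher number from compound 2 to compound 4 (0.16 log units; within the scatter) shows that this double bond on the nitrogen leaves the number where compound 2 had it. The allyl chain also sharpens the contrast with the hydroxylated chain: a 13-fold higher number from compound 3 to compound 4 (1.11 log units; beyond the scatter) is the largest step in this set, so compounds 1, 2 and 4, which carry no hydroxyl group, all stay well clear of compound 3. Among these three chains without hydroxyl groups, a 2.4-fold higher number from compound 1 to compound 4 (0.38 log units; beyond the scatter) is the first step to pass the scatter, yet compound 2 lies within the scatter of both, so the short chains form a loose group and not a clear order.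

On these data alone, it remains open whether a longer chain on this nitrogen would stay with these three compounds, and whether an amine or a carboxylic acid on the chain would shift the number as the 2,3-dihydroxypropyl chain does. Nothing given here accounts for why the number moves with these chains.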